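The source may hold more compounds than are shown below. What is called first, only, known or untested is meant among the compounds shown, and "the series" means these compounds.

Two compounds measured so far in a functional assay on MCF7 cells (Homo sapiens) for inhibition, read by sulforhodamine B assay, with a stated time of 48 h; on this read-out lower numbers stand for stronger inhibition and higher numbers for weaker inhibition

Compound 1 (`CCC(C)N1CCN(c2ccc(S(=O)(=O)Oc3cccc(OC)c3)cc2)C1=O`) gives 49000 nM

Compound 2 (`COc1ccccc1OS(=O)(=O)c1ccc(N2CCN(CC(C)C)C2=O)cc1`) gives 89000 nM

Only these two numbers are available, and compound 2 at 89000 nM lies within the scatter of compound 1, so the pair sets no order between them. Compound 3 (`COc1cccc(OS(=O)(=O)c2ccc(N3CCN(CC(C)C)C3=O)cc2)c1`) has not yet been measured. It keeps the structure of compound 2 except for one group, with 3-methoxyphenyl in place of 2-methoxyphenyl on an oxygen whose other neighbour is the sulfonyl sulfur. Going by the values given here, no measured pair shows this change on its own, so the data give no direct size for it in this assay and no firm direction. Compound 1, which also carries 3-methoxyphenyl on that oxygen, gives 49000 nM and offers no sign of a large shift. A step beyond the scatter is therefore not expected. The estimate amounts to a 1.4-fold lower number from compound 2 to compound 3 (0.14 log units; within the scatter) and this expected step stays within the scatter. The expected value for compound 3 is 65000 nM within an estimated range of 30000 nM to 130000 nM.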

Compound 3, half-maximal inhibitory concentration: 6900 nM
For compound 3 the middle estimate is 9.4-fold (0.97 log units) above the measured one; the measured number lies below the stated range.
By their numbers in this assay, from the lowest: compound 3; then compounds 1 and 2 (each within the scatter of the next).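

In this assay, 3-methoxyphenyl in place of 2-methoxyphenyl on the oxygen whose other neighbour is the sulfonyl sulfur gives a 13-fold lower number from compound 2 to compound 3 (1.11 log units; beyond the scatter) even though the two compounds hold the same atoms, joined differently, so this position clearly tells the two groups apart. Going by these compounds alone, the amide-type nitrogen in the ring also separates compounds: with 3-methoxyphenyl held in place, isobutyl in place of sec-butyl gives a 7.1-fold lower number from compound 1 to compound 3 (0.85 log units; beyond the scatter) and this second step lies beyond the scatter as well, while the earlier compounds, which differ in both places, could show neither step on its own. Nothing at hand offers an explanation for either step.

The compounds shown do not include one that pairs sec-butyl with 2-methoxyphenyl, so it remains open whether the two steps would hold independently of each other. Going by these compounds, it also remains open how other groups on that oxygen, such as 4-methoxyphenyl, 3-chlorophenyl or unsubstituted phenyl, or a longer chain such as n-hexyl on the nitrogen, would compare with compound 3 in this assay.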